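Furan in Place of Thiazole on the Amine Carbon

The source may report more compounds than this note shows. Statements on the series, on what has been measured and on what is new or still open speak of the compounds shown alone.

Compound 1 `C[C@H]1[C@H](NCc2cncs2)C[C@H]2C[C@@H]1C2(C)C` was examined in an ADME assay on MDCK cells (Canis lupus familiaris) for cytotoxicity, read by microscopy, with a stated time of 48 h; on this read-out higher numbers stand for lower toxicity in this test and lower numbers for higher toxicity in this test. In this assay compound 1 gives > 100000 nM, which is a limit of the assay and not a number. Compound 2 `C=Cc1csc(CN[C@@H]2C[C@H]3C[C@@H]([C@H]2C)C3(C)C)c1` gives 6250 nM in this assay. Compound 1 therefore stands at the limit of > 100000 nM in this assay, at which 1 of the 2 values shown sits. Compound 3 `C[C@H]1[C@H](NCc2ccoc2)C[C@H]2C[C@@H]1C2(C)C` differs from compound 1 by furan-3-yl in place of 1,3-thiazol-5-yl on a saturated chain carbon bound to an amine nitrogen. Among the measured compounds shown here, no measured step between two compounds accompanies this change. The step of a number no higher from compound 1 to compound 3 (the limit leaves the size open) is expected to stay within the scatter, in no set direction. Compound 3 is estimated at 100000 nM, with a range from 25000 nM to 200000 nM.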

Compound 3, minimum cytotoxic concentration: > 100000 nM
Compound 3: a limit, no number; the forecaster's own chance of this, stated with the estimate: 60%; the middle value lies on the limit itself.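

In this assay no step can be read between compound 1 and compound 3, since each stands at a limit and not at a number: the limit of > 100000 nM in this assay, at which 2 of the 3 values shown sit. On these data alone, whether furan-3-yl in place of 1,3-thiazol-5-yl shifts the read-out at all stays open.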